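This account rests on a few compounds, and the source may have more. Where it says the series, first, only, none or still open, it means among the compounds named here.

Working notes on the series. In a functional assay on U-87MG ATCC cells (Homo sapiens) for cytotoxicity, read by MTT assay, with a stated time of 72 h (a lower number here means a stronger inhibitor, a higher number a weaker inhibitor), compound 1 `CCN(CC)Cc1ccc(-c2ccnc3ccc(-c4cnc(OC)c(NS(=O)(=O)c5ccc(F)cc5F)c4)cc23)cc1` gives 4890 nM. Compound 2 `CNCCN(C)Cc1ccc(-c2ccnc3ccc(-c4cnc(OC)c(NS(=O)(=O)c5ccc(F)cc5F)c4)cc23)cc1` gives 254 nM in this assay, and compound 3 `COc1ncc(-c2ccc3nccc(-c4ccc(CN5CCCC5)cc4)c3c2)cc1NS(=O)(=O)c1ccc(F)cc1F` gives 159 nM in this assay. Compound 3 carries the lowest number of the three: a 31-fold lower number from compound 1 to compound 3 (1.49 log units; beyond the scatter) lies beyond the scatter, whereas a 1.6-fold lower number from compound 2 to compound 3 (0.20 log units; within the scatter) does not, so compound 2 and compound 3 cannot be ordered. Compound 4 `COc1ncc(-c2ccc3nccc(-c4ccc(CN5CCCCC5)cc4)c3c2)cc1NS(=O)(=O)c1ccc(F)cc1F` differs from compound 3 by piperidin-1-yl in place of pyrrolidin-1-yl on a saturated chain carbon bound to an aromatic carbon. For the measured compounds named here, the steps that bear on this position are a 19-fold lower number from compound 1 to compound 2 (1.28 log units; beyond the scatter) and a 31-fold lower number from compound 1 to compound 3 (1.49 log units; beyond the scatter); both replaced diethylamino, and the two cyclic or chain amines that entered sit close together. A six-membered ring in place of the five-membered ring has not been measured, so the expected step of a 1.3-fold higher number from compound 3 to compound 4 (0.10 log units; within the scatter) is small, within the scatter. Compound 4 is estimated at 200 nM, in the range 80 nM to 500 nM.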

Compound 4, half-maximal inhibitory concentration: 32 nM
Estimate against measurement, compound 4: 6.3-fold (0.80 log units) above; the measured number lies below the stated range.
By their numbers in this assay, from the lowest: compound 4; then compounds 3 and 2 (each within the scatter of the next); then compound 1.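

In this assay, for the compounds shown here, this position responds to ring size among the cyclic amines, which the earlier compounds could not show: a 5.0-fold lower number from compound 3 to compound 4 (0.70 log units; beyond the scatter) lies beyond the scatter, so piperidin-1-yl and pyrrolidin-1-yl are not interchangeable here. Piperidin-1-yl also separates from both open-chain amines, with a 7.9-fold lower number from compound 2 to compound 4 (0.90 log units; beyond the scatter) and a 150-fold lower number from compound 1 to compound 4 (2.18 log units; beyond the scatter), and compound 4 carries the lowest number of the four, beyond the scatter of each other compound. No measurement offered here explains these steps. Open, on these data alone, is how azepan-1-yl, morpholin-4-yl or 4-methylpiperazin-1-yl would read on this saturated chain carbon.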